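Extending hydroxymethyl to 2-hydroxyethyl on a shared core

The source may hold more compounds than are shown below. What is called first, only, known or untested is meant among the compounds shown, and "the series" means these compounds.

Among the compounds with values here, in a functional assay on HeLa cells (Homo sapiens) for antiproliferative activity, read by sulforhodamine B assay (on this read-out higher numbers stand for weaker inhibition of growth and lower numbers for stronger inhibition of growth), compound 3 `OC[C@@H]1O[C@H](COCc2ccccc2)[C@@H](OCc2ccccc2)[C@H](OCc2ccccc2)[C@H]1O` gives 25800 nM as one of only two numbers available. Compound 2 `C=CC[C@@H]1O[C@H](COCc2ccccc2)[C@@H](OCc2ccccc2)[C@H](OCc2ccccc2)[C@H]1O` gives 26200 nM and the two values lie within the scatter of each other. Compound 1 `O[C@H]1CO[C@H](COCc2ccccc2)[C@@H](OCc2ccccc2)[C@@H]1OCc1ccccc1` gives > 50000 nM which is a limit of the assay and not a number. The steps of an at least 1.9-fold lower number from compound 1 to compound 2 (0.28 log units; that floor lies within the scatter) and an at least 1.9-fold lower number from compound 1 to compound 3 (0.28 log units; that floor lies within the scatter) rest on that limit and give only floors.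

The change to compound 4 `OCC[C@@H]1O[C@H](COCc2ccccc2)[C@@H](OCc2ccccc2)[C@H](OCc2ccccc2)[C@H]1O` is hydroxymethyl in place of hydroxy on a saturated chain carbon bound to a saturated ring carbon. The closest guide is the swap at that same place, a 1.0-fold lower number from compound 2 to compound 3 (0.01 log units; within the scatter) and this small step suggests that no change beyond the scatter should be expected in this assay here. The estimated step is a 1.0-fold lower number from compound 3 to compound 4 (0.01 log units; within the scatter) and it is expected to stay small. For compound 4 the expected value is 25000 nM with 12000 nM to 50000 nM as the estimated range.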

Compound 4, concentration for 50% growth inhibition: 30200 nM
Beside the measured number, compound 4's estimate is 1.2-fold (0.08 log units) below it, and the stated range covers the measured number.
By their numbers in this assay, from the lowest: compounds 3, 2 and 4 (each within the scatter of the next). At a limit, above all of these: compound 1.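

In this assay, within the data shown here, the earlier compounds offered only one swap at this saturated chain carbon bound to a saturated ring carbon, and compound 4 adds a second, with a 1.2-fold higher number from compound 3 to compound 4 (0.07 log units; within the scatter). Set against the vinyl end of compound 2, the new group also gives a step of the same kind, with a 1.2-fold higher number from compound 2 to compound 4 (0.06 log units; within the scatter), so three different groups at this place now give values within the scatter of one another, and going from hydroxymethyl to 2-hydroxyethyl opens no gap on the shared core. Only a floor can be read for the step that rests on a limit, an at least 1.6-fold lower number from compound 1 to compound 4 (0.21 log units; that floor lies within the scatter): the limit of > 50000 nM in this assay, at which 1 of the 4 values shown sits.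

What these compounds leave open is whether an amine, a carboxylic acid or a longer chain at this place would give a step beyond the scatter. They also do not show what the terminal hydroxy contributes, if anything, on this core.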